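Cyano in place of nitro: compound 3 to compound 4

The compounds below may be only part of what the source reports. "The series", "measured", "known", "first", "only" and "open" are said of these compounds alone.

In a functional assay on LNCaP cells (Homo sapiens) for cytotoxicity, read by sulforhodamine B assay, with a stated time of 72 h (a lower number here means a stronger inhibitor, a higher number a weaker inhibitor), compound 3 (`COc1ccc(/C=C/C(=O)/C=C(O)/C=C/c2ccc(OC(C)(C)C(=O)Nc3ccc([N+](=O)[O-])c(C(F)(F)F)c3)c(OC)c2)cc1OC`) reads > 100000 nM as a limit. Compound 1 (`COc1cc(/C=C/C(=O)/C=C(O)/C=C/c2ccc(OC(C)(C)C(=O)Nc3ccc([N+](=O)[O-])c(C(F)(F)F)c3)c(OC)c2)ccc1O`) reads > 100000 nM as a limit too. The change to compound 4 (`COc1ccc(/C=C/C(=O)/C=C(O)/C=C/c2ccc(OC(C)(C)C(=O)Nc3ccc(C#N)c(C(F)(F)F)c3)c(OC)c2)cc1OC`) is cyano in place of nitro on an aromatic carbon, ortho to a trifluoromethyl group and para to a large group (cyano in place of nitro on an aromatic carbon). The same swap has been measured once, and there compound 2 (`COc1cc(/C=C/C(=O)/C=C(O)/C=C/c2ccc(OC(C)(C)C(=O)Nc3ccc(C#N)c(C(F)(F)F)c3)c(OC)c2)ccc1O`) gives 55000 nM as a true number. That pair shows an at least 1.8-fold lower number from compound 1 to compound 2 (0.25 log units; that floor lies within the scatter) and so offers a floor, not a size. As far as these compounds go, the methyl step (a step that the two limits leave unreadable from compound 1 to compound 3) cannot be sized, so how the two changes combine stays open, with the limit of > 100000 nM in this assay, at which 2 of the 3 values shown sit, as the ceiling of the read-out. On the pair with compound 2 (an at least 1.8-fold lower number from compound 1 to compound 2 (0.25 log units; that floor lies within the scatter)) alone, a lower number is expected in this assay after the swap. The estimated step is an at least 1.6-fold lower number from compound 3 to compound 4 (0.22 log units; that floor lies within the scatter) and a second limit reading remains possible. For compound 4 the estimate is 60000 nM with a range from 25000 nM to 100000 nM expected.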

Compound 4, half-maximal inhibitory concentration: > 100000 nM
Compound 4: a limit, no number (the forecaster's own chance of this, stated with the estimate: 35%); middle value at least 1.6-fold (0.22 log units) from the limit.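

In this assay compound 4 reads > 100000 nM, and that is a limit. Cyano in place of nitro on this aromatic carbon therefore gave a true number with compound 2 but not with compound 4, so the gain seen in the first pair does not carry over to the analogue with methyl on the oxygen, and the steps between two limits cannot be read because both ends sit at the ceiling of the read-out: the limit of > 100000 nM in this assay, at which 3 of the 4 values shown sit.

For the compounds shown here, the one readable new step, methyl in place of hydrogen on an oxygen on an aromatic ring, is an at least 1.8-fold higher number from compound 2 to compound 4 (0.25 log units; that floor lies within the scatter), and it gives a floor only.

As far as these compounds go, the size of the swap on this methylated analogue stays open, as does how the two changes combine. Also open, from the compounds shown here alone, is whether an amine or a carboxylic acid on this aromatic carbon would give a true number in this assay.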